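The source may hold more compounds than are shown below. What is called first, only, known or untested is meant among the compounds shown, and "the series" means these compounds.

Measured in a functional assay on A549 cells (Homo sapiens) for inhibition, read by sulforhodamine B assay, with a stated time of 48 h; on this read-out higher numbers stand for weaker inhibition of growth and lower numbers for stronger inhibition of growth:
- Compound 1 `COc1ccc(OC)c(C=C(C(=O)/C=C/c2ccc(O)c(OC)c2)C(=O)/C=C/c2ccc(O)c(OC)c2)c1`: 670 nM
- Compound 2 `COc1cc(/C=C/C(=O)C(=Cc2ccc(OC)c(OC)c2)C(=O)/C=C/c2ccc(O)c(OC)c2)ccc1O`: 430 nM
- Compound 3 `COc1cc(/C=C/C(=O)C(=Cc2cccc(F)c2)C(=O)/C=C/c2ccc(O)c(OC)c2)ccc1O`: 360 nM

The three compounds share one core and differ only in a single aryl group. Compound 3 cannot be separated from the other two, since a 1.2-fold lower number from compound 2 to compound 3 (0.08 log units; within the scatter) and a 1.9-fold lower number from compound 1 to compound 3 (0.27 log units; within the scatter) both remain within the scatter.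

Compound 4 `COc1cc(/C=C/C(=O)C(=Cc2cccc(OC)c2OC)C(=O)/C=C/c2ccc(O)c(OC)c2)ccc1O` differs from compound 3 as follows: 2,3-dimethoxyphenyl in place of 3-fluorophenyl on a double-bonded chain carbon bound to a double-bonded chain carbon. In words, 2,3-dimethoxyphenyl stands in place of 3-fluorophenyl on a double-bonded chain carbon bound to a double-bonded chain carbon.

The closest evidence comes from the two measured steps that make the reverse kind of exchange, a dimethoxyphenyl group giving way to 3-fluorophenyl: a 1.9-fold lower number from compound 1 to compound 3 (0.27 log units; within the scatter) and a 1.2-fold lower number from compound 2 to compound 3 (0.08 log units; within the scatter). Moving between dimethoxyphenyl patterns also gave only a small step, a 1.6-fold lower number from compound 1 to compound 2 (0.19 log units; within the scatter). For the measured compounds named here, none of these steps exceeds the scatter, although no compound yet carries the 2,3-dimethoxyphenyl pattern. In this assay, at most a small rise in the number is therefore expected. The expected step is a 1.3-fold higher number from compound 3 to compound 4 (0.12 log units; within the scatter), which would not go beyond the scatter. For compound 4 the estimated value is 480 nM, with an expected range from 240 nM to 950 nM.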

Compound 4, concentration for 50% growth inhibition: 420 nM
Estimate against measurement, compound 4: 1.1-fold (0.06 log units) above; low and high end bracket the measured number.
By their numbers in this assay, from the lowest: compounds 3, 4, 2 and 1 (each within the scatter of the next).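

In this assay, the 2,3-dimethoxyphenyl group on a double-bonded chain carbon bound to a double-bonded chain carbon cannot be told apart from any of the three aryl groups seen earlier: a 1.2-fold higher number from compound 3 to compound 4 (0.07 log units; within the scatter), a 1.0-fold lower number from compound 2 to compound 4 (0.01 log units; within the scatter) and a 1.6-fold lower number from compound 1 to compound 4 (0.20 log units; within the scatter) all remain within the scatter. For the compounds shown here, this adds a third dimethoxyphenyl pattern to the set and gives the first direct exchange of 3-fluorophenyl for a group of this kind starting from compound 3; although the entering group carries 2 hydrogen-bond acceptors and the leaving group 0, the number does not move beyond the scatter. Nothing available here accounts for the four compounds reading alike at this position.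

All four compounds carry a six-membered aromatic ring of carbon only at this place, so the compounds shown leave open whether an amine, a carboxylic acid or a longer chain there would produce a step beyond the scatter. The rest of the shared core is also the same throughout, so they say nothing about how a change elsewhere, such as replacing a hydroxyl group with a methoxy group, would read in this assay.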